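Benzyl variation across two amide cores

The source may report more compounds than this note shows. Statements on the series, on what has been measured and on what is new or still open speak of the compounds shown alone.

Measured so far, in a functional assay on MKN-74 cells (Homo sapiens) for antiproliferative activity, with a stated time of 24 h; on this read-out lower numbers stand for stronger inhibition and higher numbers for weaker inhibition:
Compound 1, `NC(=O)c1c(NC(=O)c2ccccc2Cl)sc2c1CCN(Cc1ccc(Cl)cc1)C2`: compound 1 gives 18700 nM.
Compound 2, `NC(=O)c1c(NC(=O)c2ccccc2Cl)sc2c1CCN(Cc1c(Cl)cccc1Cl)C2`: compound 2 gives 4740 nM.
Compound 3, `NC(=O)c1c(NC(=O)c2ccc(C(F)(F)F)cc2)sc2c1CCN(Cc1ccc(Cl)cc1)C2`: compound 3 reaches only the limit of this assay, > 50000 nM.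

From compound 1 to compound 2 the change is 2,6-dichlorophenyl in place of 4-chlorophenyl on a saturated chain carbon bound to an amine nitrogen in a ring, and it gives a 3.9-fold lower number from compound 1 to compound 2 (0.60 log units; beyond the scatter). The two cores differ as 4-(trifluoromethyl)phenyl in place of 2-chlorophenyl on a carbonyl carbon, with an at least 2.6-fold higher number from compound 1 to compound 3 (0.42 log units; beyond the scatter). Compound 4, `NC(=O)c1c(NC(=O)c2ccc(C(F)(F)F)cc2)sc2c1CCN(Cc1c(Cl)cccc1Cl)C2`, carries the same change on the core of compound 3: 2,6-dichlorophenyl in place of 4-chlorophenyl on a saturated chain carbon bound to an amine nitrogen in a ring, at the same place as between compound 1 and compound 2. For compound 4 the expected step is an at least 2.5-fold lower number from compound 3 to compound 4 (0.39 log units; beyond the scatter), resting on a 3.9-fold lower number from compound 1 to compound 2 (0.60 log units; beyond the scatter). Because compound 3 sits at the limit of > 50000 nM in this assay, at which 1 of the 3 values shown sits, the starting point is itself only a limit, so a limit for compound 4 remains possible. Compound 4 is expected at 20000 nM, estimated between 7000 nM and 50000 nM.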

Compound 4, half-maximal inhibitory concentration: 8530 nM
The estimate for compound 4 lay 2.3-fold (0.37 log units) above the measured number, and the stated range covers the measured number.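

In this assay the change from 4-chlorobenzyl to 2,6-dichlorobenzyl carries over in direction to the core of compound 3 with an at least 5.8-fold lower number from compound 3 to compound 4 (0.76 log units; beyond the scatter) but its size from core to core stays unsettled: the same change on two cores in this assay, a 3.9-fold lower number (0.60 log units; beyond the scatter) from compound 1 to compound 2 and an at least 5.8-fold lower number (0.76 log units; beyond the scatter) from compound 3 to compound 4; the limit leaves it open whether they differ. With 2,6-dichlorobenzyl in both compounds, 4-(trifluoromethyl)phenyl in place of 2-chlorophenyl gives a 1.8-fold higher number from compound 2 to compound 4 (0.26 log units; within the scatter) and no firm difference from the 4-chlorobenzyl pair can be stated: the same change on two cores in this assay, an at least 2.6-fold higher number (0.42 log units; beyond the scatter) from compound 1 to compound 3 and a 1.8-fold higher number (0.26 log units; within the scatter) from compound 2 to compound 4; the limit leaves it open whether they differ. Compound 3 stands only as a limit, so neither comparison gives a measured gap, and two cores make no rule for the wider series: the limit of > 50000 nM in this assay, at which 1 of the 4 values shown sits.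

As far as these compounds go, it remains open whether the change holds on a third core, such as one carrying 4-methoxyphenyl on the carbonyl carbon. From the compounds shown here alone, the effect of replacing 2,6-dichlorophenyl with 2-chlorophenyl or a pyridine ring is also open.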